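Compounds Meet a Limit; Another Remains Open

The compounds below may be only part of what the source reports. "The series", "measured", "known", "first", "only" and "open" are said of these compounds alone.

Measured so far:
compound 1 `COc1cc(C(=O)c2ccc3c(ccn3S(=O)(=O)c3ccc(/C=C/C(=O)NO)cc3)c2)cc(OC)c1OC`: > 100000 nM
compound 2 `COc1ccc(C(=O)c2ccc3c(ccn3S(=O)(=O)c3ccc(/C=C/C(=O)NO)cc3)c2)cc1`: > 100000 nM
compound 3 `COc1cc(C(=O)c2ccc3c(ccn3Cc3ccc(/C=C/C(=O)NO)cc3)c2)cc(OC)c1OC`: "not determined" (no result reported)

In an assay on isolated protein for inhibition of polyamine deacetylase HDAC10 (Homo sapiens) (a lower number here means a stronger inhibitor, a higher number a weaker inhibitor), compound 1 gives > 100000 nM, which is a limit of the assay and not a number. Compound 2 likewise gives > 100000 nM in this assay, again a limit. The step that the two limits leave unreadable from compound 1 to compound 2 therefore cannot be read, a point that rests on (the limit of > 100000 nM in this assay, at which 2 of the 3 values shown sit); the change behind it is 4-methoxyphenyl in place of 3,4,5-trimethoxyphenyl on a carbonyl carbon. For compound 3 this assay shows "not determined" (no result reported). Going by the values given here, compound 4 `COc1ccc(C(=O)c2ccc3c(ccn3Cc3ccc(/C=C/C(=O)NO)cc3)c2)cc1` is not yet measured; it differs from compound 3 by 4-methoxyphenyl in place of 3,4,5-trimethoxyphenyl on a carbonyl carbon, the same change as the one from compound 1 to compound 2, made at a place described in the same words. The difference between the core of compound 1 and the core of compound 3 is not broken down here. Among the compounds with values here, the one measured example of this change gives no size that could be carried over to the step from compound 3 to compound 4. Compound 4 is expected to give roughly 5000 nM in this assay, estimated to fall between 300 nM and 100000 nM, with a fair chance that only a limit is reported.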

Compound 4, half-maximal inhibitory concentration: 7050 nM
The estimate for compound 4 lay 1.4-fold (0.15 log units) below the measured number, within the range that was stated.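

No new step can be read from this result: in this assay compound 4 gives 7050 nM, while compound 3 shows "not determined" (no result reported), which leaves this pair without a comparison. The compounds shown leave open whether, and by how much, 4-methoxyphenyl in place of 3,4,5-trimethoxyphenyl on a carbonyl carbon alters the result in this assay on either core.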